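This account rests on a few compounds, and the source may have more. Where it says the series, first, only, none or still open, it means among the compounds named here.

Compound 1 `COc1ccc(-c2c(C(=O)c3cc(OC)c(OC)c(OC)c3)sc3ccccc23)cc1` was tested in a functional assay on HL-60 cells (Homo sapiens) for antiproliferative activity, read by MTT assay, with a stated time of 72 h (on this read-out higher numbers stand for weaker inhibition and lower numbers for stronger inhibition), where compound 1 gives 1600 nM. Compound 2 `COc1ccc(-c2c(C(=O)c3cc(OC)c(OC)c(OC)c3)sc3ccccc23)cc1C` differs from compound 1 by methyl in place of hydrogen on an aromatic carbon. In this assay compound 2 reaches only a limit, > 10000 nM, which is the limit of > 10000 nM in this assay, at which 1 of the 3 values shown sits. The step is an at least 6.2-fold higher number from compound 1 to compound 2 (0.79 log units; beyond the scatter). Compound 3 `COc1cc(C(=O)c2sc3ccccc3c2Nc2ccc(C)cc2)cc(OC)c1OC` has a different core, its difference from compound 1 being ((4-methylphenyl)amino in place of 4-methoxyphenyl on an aromatic carbon); in this assay compound 3 gives 4600 nM, a step of a 2.9-fold higher number from compound 1 to compound 3 (0.46 log units; beyond the scatter). Compound 4 `COc1cc(C(=O)c2sc3cc(C)ccc3c2Nc2ccc(C)cc2)cc(OC)c1OC` differs from compound 3 by methyl in place of hydrogen on an aromatic carbon. Among the compounds with values here, this is the same kind of change as the one from compound 1 to compound 2, but not the same: in compound 2 the methyl sits ortho to a methoxy group and meta to a large group on a six-membered aromatic ring of carbon only, whereas in compound 4 it sits on a six-membered aromatic ring of carbon only that is part of a fused system of two rings, meta to a fused ring and para to a fused ring. For compound 4 a step of a 1.6-fold higher number from compound 3 to compound 4 (0.21 log units; within the scatter) in this assay is expected, a guess resting on the weakening step an at least 6.2-fold higher number from compound 1 to compound 2 (0.79 log units; beyond the scatter) tempered by the different place. Compound 4 is therefore estimated at 7500 nM, most likely between 2500 nM and 20000 nM.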

Compound 4, half-maximal inhibitory concentration: 1900 nM
Estimate against measurement, compound 4: 3.9-fold (0.60 log units) above; the whole stated range lies above it.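

In this assay the added methyl gives stronger inhibition on the core of compound 3, with a 2.4-fold lower number from compound 3 to compound 4 (0.38 log units; beyond the scatter), whereas the same kind of change gave weaker inhibition on the core of compound 1: the same change on two cores in this assay, an at least 6.2-fold higher number (0.79 log units; beyond the scatter) from compound 1 to compound 2 and a 2.4-fold lower number (0.38 log units; beyond the scatter) from compound 3 to compound 4, at least 15-fold (1.17 log units) apart, beyond the scatter of two such steps

Compound 2 gives > 10000 nM, which is a limit of the assay and not a number.

So methyl in place of hydrogen on an aromatic carbon did not carry over from one core to the other with the same direction of effect, but the two methyl groups also sit in different places, and these two pairs cannot separate the effect of the core from the effect of the place.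

The compounds shown leave open what a methyl would do in the same place on both cores, which would test that question directly. They also leave open whether an ethyl group, a chlorine atom or an amine in the place of the methyl of compound 4 would keep the stronger inhibition seen there.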